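Adding an ester to a fluorinated phthalimide-like inhibitor

The source may report more compounds than this note shows. Statements on the series, on what has been measured and on what is new or still open speak of the compounds shown alone.

Measured compounds:
Compound 1, `O=C1C2=C(CCCC2)C(=O)N1c1ccccc1F`, gives 3160 nM in an assay on isolated protein (Echinochloa esculenta) for inhibition of protoporphyrinogen oxidase, chloroplastic (Oryza sativa subsp. japonica), using a Dixon plot, with a stated time of 5 min; a higher number here means a weaker inhibitor, a lower number a stronger inhibitor.
Compound 2, `CC(C)OC(=O)c1cc(N2C(=O)C3=C(CCCC3)C2=O)ccc1Cl`, gives 2 nM in this assay.
Compound 3, `O=C1C2=C(CCCC2)C(=O)N1c1ccc(Cl)cc1F`, gives 5.01 nM in this assay.

Among these three numbers compound 3 holds the second highest, so it is the middle inhibitor. Compound 2 lies nearest to it, and compound 1 lies furthest away.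

The step now considered leads from compound 3 to compound 4, `CC(C)OC(=O)c1cc(N2C(=O)C3=C(CCCC3)C2=O)c(F)cc1Cl`. The change is isopropoxycarbonyl in place of hydrogen on an aromatic carbon.

Going by the values given here, the one measured step, a 630-fold lower number from compound 1 to compound 3 (2.80 log units; beyond the scatter), concerns a chloro group and says nothing direct about an ester. Among the compounds with values here, no measured step contains the present change. Compound 2, however, already carries an isopropoxycarbonyl group at the same place, without the fluoro group, and compound 2 gives 2 nM while compound 3 gives 5.01 nM. On that basis the number for compound 4 is expected to move little, if at all, and rather downward, with a 2.0-fold lower number from compound 3 to compound 4 (0.30 log units; within the scatter).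

Compound 4 is therefore estimated at 2.5 nM, in the range from 0.8 nM to 8 nM, in this assay.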

Compound 4, half-maximal inhibitory concentration: 7.94 nM
Beside the measured number, compound 4's estimate is 3.2-fold (0.50 log units) below it; measured number inside the range.
By their numbers in this assay, from the lowest: compound 2; then compounds 3 and 4 (each within the scatter of the next); then compound 1.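

In this assay putting isopropoxycarbonyl in place of hydrogen, on the aromatic carbon ortho to a chloro group and para to a fluoro group, gives a 1.6-fold higher number from compound 3 to compound 4 (0.20 log units; within the scatter) and so cannot be told apart from no change at all. A group far larger than a hydrogen atom is therefore accepted at this position when the fluoro group is present, with no gain in inhibition that can be read. Going by these compounds alone, with the isopropoxycarbonyl group already in place, fluoro in place of hydrogen gives a 4.0-fold higher number from compound 2 to compound 4 (0.60 log units; beyond the scatter) and this modest weakening is the only real change among the new steps; nothing measured here explains either step.

Still open, going by these compounds, is whether a carboxylic acid, a methyl ester or an amine at this same position would also leave the number where it stands. Also open is what the fluoro group does in a compound without the isopropoxycarbonyl group, a question that no pair of compounds shown here can answer.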